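Thiocarbamate in place of a fluoroethyl carbamate

A few compounds are considered here, and "the series" means these few. Any claim that something is new, unique, unknown or untested is made for them only; others in the source may bear on it.

In a functional assay on isolated protein for inhibition of Glucose-dependent insulinotropic receptor (Rattus norvegicus), read by HTRF and cAMP accumulation (a lower number here means that less compound is needed, a higher number that more compound is needed for the effect), compound 2 `Cc1nc(S(C)(=O)=O)ccc1Oc1ncnc(OC2CCN(C(=O)OC(C)F)CC2)c1F` gives 315 nM, the second highest of three numbers. Compound 1 `Cc1nc(S(C)(=O)=O)ccc1Oc1ncnc(OC2CCN(C(=O)OC(C)(C)CF)CC2)c1F` gives 138 nM, and compound 3 `Cc1nc(S(C)(=O)=O)ccc1Oc1ncnc(OC2CCN(C(=O)OC3(C(F)(F)F)COC3)CC2)c1F` gives 342 nM. The two measured steps touching compound 2 are a 2.3-fold higher number from compound 1 to compound 2 (0.36 log units; beyond the scatter) and a 1.1-fold higher number from compound 2 to compound 3 (0.04 log units; within the scatter); the group on the oxygen next to the carbonyl therefore moves the number only modestly, and in one case not beyond the scatter. Compound 4 `Cc1nc(S(C)(=O)=O)ccc1Oc1ncnc(OC2CCN(C(=O)SC3(C)CC3)CC2)c1F` differs from compound 2 in one place: a group of 5 heavy atoms (4 carbon, 1 sulfur; one three-membered non-aromatic ring of carbon only) in place of a group of 4 heavy atoms (2 carbon, 1 oxygen, 1 fluorine; no ring), on a carbonyl carbon. For the measured compounds named here, no measured pair exchanges the oxygen itself, so the expectation leans on the modest steps seen and allows a wide range. Compound 4 is expected to give 220 nM, between 70 nM and 700 nM, an estimated step of a 1.4-fold lower number from compound 2 to compound 4 (0.16 log units; within the scatter).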

Compound 4, half-maximal effective concentration: 166 nM
Compound 4: middle estimate off by 1.3-fold (0.12 log units), on the high side, and the stated range covers the measured number.
By their numbers in this assay, from the lowest: compounds 1, 4, 2 and 3 (each within the scatter of the next, the first and the last beyond it).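

In this assay the group on the carbonyl carbon can be linked through sulfur and carry a three-membered carbon ring, with a 1.2-fold higher number from compound 1 to compound 4 (0.08 log units; within the scatter) and a 1.9-fold lower number from compound 2 to compound 4 (0.28 log units; within the scatter) both inside the scatter. Only a 2.1-fold lower number from compound 3 to compound 4 (0.31 log units; beyond the scatter) lies beyond it, and modestly. The position therefore accepts a sulfur link as well as an oxygen link.

For the compounds shown here, no pair here exchanges sulfur alone for oxygen, so the separate shares of the sulfur and the ring stay open, as does the outcome with an amine on the carbonyl carbon. No measurement at hand explains the result.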